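The compounds below may be only part of what the source reports. "The series", "measured", "known", "first", "only" and "open" are said of these compounds alone.

Measured in a functional assay on MDA-MB-231 cells (Homo sapiens) for antiproliferative activity, read by MTT assay (a higher number here means a weaker inhibitor, a lower number a stronger inhibitor), so far:
Compound 1 `CCCC/C=C\CCCCCCCCCc1cc(=O)c2c(O)cc(OCOC)cc2o1` gives > 87000 nM as a limit
Compound 2 `CCCC/C=C\CCCCCCCCCc1cc(=O)c2c(O)c(C)c(OCOC)cc2o1` gives > 87000 nM as a limit
Compound 3 `CC/C=C\C/C=C\C/C=C\CCCCCCCc1cc(=O)c2c(O)c(C)c(O)c(C)c2o1` gives 6790 nM as a number

Compound 2 stands only as a limit, with > 87000 nM as its entry, and no number is known for it. Compound 4 `CCCCC/C=C\C/C=C\CCCCCCCc1cc(=O)c2c(O)c(C)c(OCOC)cc2o1` keeps the core of compound 2 and alters only the chain, as follows: deca-1,4-dien-1-yl in place of oct-3-en-1-yl on a saturated chain carbon, seven bonds along the chain from an aromatic carbon.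

Only one measured step links two of these compounds. That step, a step that the two limits leave unreadable from compound 1 to compound 2 for methyl in place of hydrogen on an aromatic carbon, concerns a different change, and its size cannot be read. Going by the values given here, compound 3 gives 6790 nM as a true number, but it differs from compound 2 in more than one place and no single step connects them. The closest guide is the limit of > 87000 nM in this assay, at which 2 of the 3 values shown sit, and on that basis compound 4 may well be reported as a limit too.

In this assay the estimated change, an at least 1.0-fold lower number from compound 2 to compound 4 (0.03 log units; that floor lies within the scatter) in this case, is expected to stay within the scatter and to have no clear direction. For compound 4 the estimate is 80000 nM with an expected range from 20000 nM to 200000 nM as its span.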

Compound 4, half-maximal inhibitory concentration: > 87000 nM
Compound 4: no number, only a limit; the forecaster's own chance of this, stated with the estimate: 70%; middle value at least 1.0-fold (0.03 log units) from the limit.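

In this assay compound 4 gives > 87000 nM, which is a limit and not a number. Going by these compounds alone, compound 2 also stands only as a limit, so no step between compound 2 and compound 4 can be read. The compounds shown leave open whether deca-1,4-dien-1-yl in place of oct-3-en-1-yl changes the activity at all.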